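The source may hold more compounds than are shown below. What is called first, only, known or untested is meant among the compounds shown, and "the series" means these compounds.

Going by the values given here, of the two compounds measured so far, compound 2 `Cc1cc(-c2c(C)nn(C)c2C)ccc1-c1nnc(N(C)Cc2ccc3nccn3c2)o1` stands lowest: in an assay on COS-7 cells for inhibition of tyrosine-protein kinase receptor UFO (Homo sapiens), read by ELISA, with a stated time of 1 h (a higher number here means a weaker inhibitor, a lower number a stronger inhibitor), compound 2 gives 398 nM. Compound 1 `Cc1nn(C)c(C)c1-c1ccc(-c2nnc(N(C)Cc3ccc4nccn4c3)o2)c(F)c1` gives 3160 nM in this assay, and the step of a 7.9-fold lower number from compound 1 to compound 2 (0.90 log units; beyond the scatter) shows that what sits on this carbon changes the number by a clear margin. Compound 3 `Cc1nn(C)c(C)c1-c1ccc(-c2nnc(N(C)Cc3ccc4nccn4c3)o2)c(C#N)c1` is not yet measured; it differs from compound 2 by cyano in place of methyl on an aromatic carbon. Among the compounds with values here, only the step from compound 1 to compound 2 bears on this exchange, and it concerns a different pair of groups at the same place, so it says that the position matters but not which way a cyano group will move the number. The expected step, a 2.0-fold higher number from compound 2 to compound 3 (0.30 log units; within the scatter), is therefore small and carries a wide range. Compound 3 is estimated at 800 nM, between 250 nM and 3000 nM.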

Compound 3, half-maximal inhibitory concentration: > 31600 nM
Compound 3 ended at the assay's limit (the forecaster's own chance of this, stated with the estimate: 5%); at least 39-fold (1.59 log units) between middle value and limit.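

Compound 3 reaches a limit of this assay, so its result is a bound and not a number: the limit of > 31600 nM in this assay, at which 1 of the 3 values shown sits. Even as a bound, putting cyano in place of methyl gives an at least 79-fold higher number from compound 2 to compound 3 (1.89 log units; beyond the scatter), and putting cyano in place of fluoro gives an at least 10-fold higher number from compound 1 to compound 3 (1.00 log units; beyond the scatter), which makes compound 3 the weakest of the three. The earlier compounds shown here showed only that this aromatic carbon responds to a change of group, whereas the order is now methyl, then fluoro, then cyano, with cyano far from the other two.

The compounds shown do not tell how far past the limit compound 3 lies, or what sets cyano apart from methyl and fluoro. Going by these compounds, how a chloro, methoxy or amino group on this same carbon would compare with methyl remains open.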